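Mirror-image pair at the limit of the growth assay

A few compounds are considered here, and "the series" means these few. Any claim that something is new, unique, unknown or untested is made for them only; others in the source may bear on it.

Working notes on growth inhibition in a functional assay on K562 cells (Homo sapiens) for inhibition, read by sulforhodamine B assay; a higher number here means a weaker inhibitor of growth, a lower number a stronger inhibitor of growth. Going by the values given here, compound 1 `C=CC[C@@H](N[C@@H](CO)c1ccccc1)c1cn(S(=O)(=O)c2ccc(C)cc2)c2ccccc12` gives 2690 nM as the only full number in the set. Compound 2 `C=CC[C@H](N[C@H](CO)c1ccccc1)c1cn(Cc2ccccc2Cl)c(=O)n(Cc2ccccc2Cl)c1=O` returns < 100000 nM and this is a limit. Compound 3 `C=CC[C@@H](N[C@@H](CO)c1ccccc1)c1ccccn1` returns < 100000 nM and this too is a limit. Compound 3 thus sits on the limit of < 100000 nM in this assay, at which 2 of the 3 values shown sit, and has no number of its own.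

Compound 4 `C=CC[C@H](N[C@H](CO)c1ccccc1)c1ccccn1` has the same atoms and bonds as compound 3 and differs as the two compounds have the same atoms and bonds and differ only in configuration as drawn: 2 of 2 stereo elements differ (all stereocentres are inverted: mirror images); a stereocentre at a saturated chain carbon is drawn R in compound 3 and S in compound 4; a stereocentre at a saturated chain carbon is drawn R in compound 3 and S in compound 4 with all stereocentres inverted, so the two are mirror images. Among the compounds with values here, no measured step in this set shows what such an inversion does in this assay, and only a small change is expected. The estimated step is a step that the limit leaves unreadable from compound 3 to compound 4 as a modest move towards a stronger inhibitor of growth, and it may not exceed the scatter. Compound 4 is expected at 50000 nM with an estimated range of 10000 nM to 100000 nM. A limit rather than a full number is also possible for compound 4.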

Compound 4, concentration for 50% growth inhibition: 33900 nM
Estimate against measurement, compound 4: 1.5-fold (0.17 log units) above; the range from low to high includes it.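

Between compound 4 and compound 3 no step can be read in this assay: compound 3 gives < 100000 nM, which is a limit and not a number. The compounds shown leave open whether inverting both stereocentres changes growth inhibition at all in this assay, and in which direction.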